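The source may report more compounds than this note shows. Statements on the series, on what has been measured and on what is new or still open speak of the compounds shown alone.

Measured so far:
compound 1 `O=C(CCCCCCn1cc(Nc2ncc3ccn(Cc4ccccc4Cl)c3n2)cn1)NO` gives 41.5 nM
compound 2 `O=C(CCCCCn1cc(Nc2ncc3ccn(Cc4cccc(F)c4)c3n2)cn1)NO` gives 13.7 nM

Both were tested in an assay on isolated protein for inhibition of protein deacetylase HDAC6 (Homo sapiens), with a stated time of 60 min; a lower number here means a stronger inhibitor, a higher number a weaker inhibitor. Compound 2 has the lower of the two numbers; compound 1 is the nearest and sits clearly higher, beyond the usual scatter. Compound 3 `O=C(CCCCCCn1cc(Nc2ncc3ccn(Cc4cccc(F)c4)c3n2)cn1)NO` has not yet been measured. It differs from compound 2 only in the chain leading to the hydroxycarbamoyl end: (hydroxycarbamoyl)methyl in place of hydroxycarbamoyl on a saturated chain carbon, five bonds along the chain from an aromatic nitrogen. Compound 1 shares that longer chain but differs elsewhere, so its value is only a loose hint. A small step is expected, perhaps toward a weaker inhibitor, not beyond the scatter: a 1.5-fold higher number from compound 2 to compound 3 (0.16 log units; within the scatter). Compound 3 is estimated at 20 nM, between 8 nM and 50 nM.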

Compound 3, half-maximal inhibitory concentration: 14.7 nM
Compound 3: middle estimate off by 1.4-fold (0.13 log units), on the high side, within the range that was stated.
By their numbers in this assay, from the lowest: compounds 2 and 3 (each within the scatter of the next); then compound 1.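

In this assay (hydroxycarbamoyl)methyl in place of hydroxycarbamoyl gives a 1.1-fold higher number from compound 2 to compound 3 (0.03 log units; within the scatter) and so this longer chain performs like the shorter one. With that longer chain kept, 3-fluorophenyl in place of 2-chlorophenyl gives a 2.8-fold lower number from compound 1 to compound 3 (0.45 log units; beyond the scatter) and so this change does move the number. No supporting data explain either result.

Still open, as far as these compounds go, is whether a longer chain, such as 4-(hydroxycarbamoyl)butyl, would also leave the number unchanged. From the compounds shown here alone, how 3-chlorophenyl or 2-fluorophenyl would compare also remains open.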